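Swapping the Last Propanoyl on Compound 1

The source may hold more compounds than are shown below. What is called first, only, known or untested is meant among the compounds shown, and "the series" means these compounds.

Compound 1 `CCC(=O)OCC(COP(=O)(O)O)Cn1cnc2c(NC)nc(Cl)nc21` gives 21000 nM
Compound 2 `CCC(=O)OCC(COC(=O)CC)Cn1cnc2c(NC)nc(Cl)nc21` gives 23000 nM
Compound 3 `CNc1nc(Cl)nc2c1ncn2CC(COP(=O)(O)O)COP(=O)(O)O` is not yet measured

Within the data shown here, in a functional assay for inhibition, with Rattus norvegicus as the target (a higher number here means a weaker inhibitor, a lower number a stronger inhibitor), compound 1 stands level with compound 2, its only measured neighbour, and neither can be ranked above the other. The change to compound 3 is a group of 4 heavy atoms (3 oxygen, 1 phosphorus; no ring) in place of a group of 4 heavy atoms (3 carbon, 1 oxygen; no ring), on an oxygen on a saturated carbon, so that no propanoyl remains. Among the measured compounds shown here, the one measured step bearing on this is the same exchange in the opposite direction, a 1.1-fold higher number from compound 1 to compound 2 (0.04 log units; within the scatter), and it lies within the scatter. For the measured compounds named here, compound 1 still holds a propanoyl, however, and no measured compound shows the state without one, so that step is a weak guide. A lower number is therefore expected, on thin evidence, as the estimated 5.3-fold lower number from compound 1 to compound 3 (0.72 log units; beyond the scatter) in this assay. Compound 3 is expected at 4000 nM, with an estimated range from 300 nM to 25000 nM in this assay.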

Compound 3, inhibition constant: 300 nM
Compound 3: the middle estimate sits 13-fold (1.12 log units) above what was measured; measured number inside the range.
By their numbers in this assay, from the lowest: compound 3; then compounds 1 and 2 (each within the scatter of the next).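

In this assay, the exchange of propanoyl for the phosphorus-bearing group on this oxygen gives a 70-fold lower number from compound 1 to compound 3 (1.85 log units; beyond the scatter), a large step, whereas the same exchange read in the opposite direction on the other oxygen, a 1.1-fold higher number from compound 1 to compound 2 (0.04 log units; within the scatter), lay within the scatter. The earlier pair therefore showed no effect of this kind of change, and the new result shows that its size is not constant: it appears here, where the last propanoyl leaves and the phosphorus-bearing group then stands on both oxygens. No measurement shown gives a reason for this step.

The compounds shown leave open whether the phosphorus-bearing group itself is required at this oxygen, or whether a carboxylic acid or a free hydroxyl there would give a similar number. They also leave open whether a longer acyl chain would differ from propanoyl.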